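The source may report more compounds than this note shows. Statements on the series, on what has been measured and on what is new or still open speak of the compounds shown alone.

In a functional assay on HL-60 cells (Homo sapiens) for cytotoxicity, read by MTT assay, with a stated time of 48 h (on this read-out lower numbers stand for stronger inhibition and higher numbers for weaker inhibition), compound 1 `N#Cc1ccc(Cn2c(/C=C3\SC(=S)N(CC(=O)O)C3=O)nc3ccccc32)cc1` gives 7640 nM and compound 2 `O=C(O)CN1C(=O)/C(=C/c2nc3ccccc3n2Cc2ccc([N+](=O)[O-])cc2)SC1=S` gives 5320 nM as its reading. Putting nitro in place of cyano on the aromatic carbon gives a 1.4-fold lower number from compound 1 to compound 2 (0.16 log units; within the scatter) and so the two numbers cannot be told apart, which leaves compound 2 level with compound 1 rather than ahead of it. Compound 3 `O=C(O)CN1C(=O)/C(=C/c2nc3ccccc3n2Cc2ccc(C(F)(F)F)cc2)SC1=S` has not been measured yet. It keeps the shared core but carries trifluoromethyl in place of nitro on an aromatic carbon on the same six-membered aromatic ring of carbon only, para to a large group. Going by the values given here, only one measured step bears on this change, the swap at that same carbon, and its size was a 1.4-fold lower number from compound 1 to compound 2 (0.16 log units; within the scatter) as noted. Among the compounds with values here, no compound with trifluoromethyl has been measured, so this guide is thin. A second swap at this carbon is therefore expected to move the number in this assay by nothing beyond the scatter, in either direction. The expected size is a 1.1-fold higher number from compound 2 to compound 3 (0.05 log units; within the scatter) and remains only an estimate. Compound 3 is estimated at 6000 nM with an expected range from 2800 nM to 13000 nM.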

Compound 3, half-maximal inhibitory concentration: 3560 nM
For compound 3 the middle estimate is 1.7-fold (0.23 log units) above the measured one; low and high end bracket the measured number.
By their numbers in this assay, from the lowest: compounds 3, 2 and 1 (each within the scatter of the next, the first and the last beyond it).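

In this assay, going by these compounds alone, trifluoromethyl in place of nitro gives a 1.5-fold lower number from compound 2 to compound 3 (0.17 log units; within the scatter) and so the two groups cannot be told apart here, while trifluoromethyl in place of cyano gives a 2.1-fold lower number from compound 1 to compound 3 (0.33 log units; beyond the scatter) and this is the first step at this position to clear the usual scatter, though only modestly. The carbon on the six-membered aromatic ring therefore does respond to the group it carries, but across the three groups the whole span remains small, and compound 2 cannot be separated from either of the other two. Nothing in the available data explains why trifluoromethyl and the nitrile differ.

The compounds shown leave open whether a group of a different kind on this carbon, such as an amine, a carboxylic acid or a longer alkyl chain, would move the number much further or would stay within this small span. They also leave open whether trifluoromethyl would give a similar result at another carbon of the same ring, since every group compared here sits at the same place.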